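The source may hold more compounds than are shown below. What is called first, only, known or untested is meant among the compounds shown, and "the series" means these compounds.

Measured so far in an assay on DDT1 cells (Cricetulus griseus) for binding affinity to adenosine receptor A1 (Homo sapiens), read by radioligand binding; a higher number here means a weaker inhibitor, a lower number a stronger inhibitor:
- compound 1, `O=C(NCc1ccccc1)OC[C@H]1OC(n2cnc3c(NC4CCOC4)ncnc32)[C@H](O)[C@@H]1O`: compound 1 gives 1830 nM
- compound 2, `O[C@@H]1[C@@H](CO/C(S)=N/Cc2ccccc2)OC(n2cnc3c(NC4CCOC4)ncnc32)[C@@H]1O`: compound 2 gives 12 nM

Within the data shown here, compound 2 holds the lower of the two numbers; the single measured step, a 150-fold lower number from compound 1 to compound 2 (2.18 log units; beyond the scatter), separates the two. Compound 3, `CN(C)C(=O)OC[C@H]1OC(n2cnc3c(NC4CCOC4)ncnc32)[C@H](O)[C@@H]1O`, differs from compound 2 by a group of 5 heavy atoms (3 carbon, 1 nitrogen, 1 oxygen; no ring) in place of a group of 10 heavy atoms (8 carbon, 1 nitrogen, 1 sulfur; one six-membered aromatic ring of carbon only), on an oxygen on a saturated carbon. Among the measured compounds shown here, only that one step bears on this change, and only in part: compound 3 carries a carbonyl on the side-chain oxygen, as compound 1 does, while the sulfur-bearing group of compound 2 is gone. A move back toward the number of compound 1 is therefore expected, a 100-fold higher number from compound 2 to compound 3 (2.00 log units; beyond the scatter). Compound 3 is estimated at 1200 nM, with a range of 300 nM to 5000 nM.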

Compound 3, inhibition constant: 238 nM
The estimate for compound 3 lay 5.0-fold (0.70 log units) above the measured number; the measured number lies below the stated range.
By their numbers in this assay, from the lowest: compound 2; then compound 3; then compound 1.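

In this assay, with the carbonyl group kept on the side-chain oxygen, the amine alone moves the number: dimethylamino in place of benzylamino gives a 7.7-fold lower number from compound 1 to compound 3 (0.89 log units; beyond the scatter). The benzyl group is therefore no requirement at this position, yet the dimethylcarbamoyl group does not match the sulfur-bearing group, with a 20-fold higher number from compound 2 to compound 3 (1.30 log units; beyond the scatter). No measurement available here explains either step. Open, on these data alone, is whether a dimethylamino group on the sulfur-bearing side chain would give a still lower number. Also open, as far as these compounds go, is how cyclic amines such as morpholine or longer chains such as phenethylamine behave on the carbonyl carbon.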